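The source may report more compounds than this note shows. Statements on the series, on what has been measured and on what is new or still open speak of the compounds shown alone.

Measured so far in a functional assay on HepG2 cells (Homo sapiens) for antiproliferative activity, read by MTT assay, with a stated time of 48 h; on this read-out lower numbers stand for stronger inhibition and higher numbers for weaker inhibition:
- compound 1 `CCN(CC)CCCCOc1c(OC)cc2oc(-c3ccccc3)cc(=O)c2c1O`, 7100 nM
- compound 2 `COc1cc2oc(-c3ccccc3)cc(=O)c2c(O)c1OCCCN1CCN(C)CC1`, 15100 nM

Compound 2 gives the highest of the two numbers in this assay, its nearest neighbour being compound 1. Going by the values given here, the one measured step bearing on the chain end is a 2.1-fold higher number from compound 1 to compound 2 (0.33 log units; beyond the scatter), modest but beyond the scatter. Compound 3 `COc1cc2oc(-c3ccccc3)cc(=O)c2c(O)c1OCCCCN1CCCC1` differs from compound 2 by (pyrrolidin-1-yl)methyl in place of 4-methylpiperazin-1-yl on a saturated chain carbon, three bonds along the chain from an oxygen on an aromatic ring. Because a 2.1-fold higher number from compound 1 to compound 2 (0.33 log units; beyond the scatter) moved the number up when the 4-methylpiperazin-1-yl group entered, its removal for a single-nitrogen ring is expected to move the number back down, with compound 3 expected to show a 2.0-fold lower number from compound 2 to compound 3 (0.30 log units; within the scatter). Compound 3 is thus estimated at 7500 nM, within a range of 3500 nM to 16000 nM.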

Compound 3, half-maximal inhibitory concentration: 4900 nM
For compound 3 the middle estimate is 1.5-fold (0.18 log units) above the measured one; the range from low to high includes it.
By their numbers in this assay, from the lowest: compounds 3 and 1 (each within the scatter of the next); then compound 2.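

In this assay, the change from 3-(4-methylpiperazin-1-yl)propyl to 4-(pyrrolidin-1-yl)butyl gives a 3.1-fold lower number from compound 2 to compound 3 (0.49 log units; beyond the scatter) and thus sets the 4-methylpiperazin-1-yl end apart from a second chain end. With pyrrolidin-1-yl in place of diethylamino, the step is a 1.4-fold lower number from compound 1 to compound 3 (0.16 log units; within the scatter) and does not separate these two ends on this read-out. No supporting evidence bears on the reason for this difference.

As far as these compounds go, compound 2 and compound 3 differ in both ring and chain length, so the contribution of each remains open. A 3-(pyrrolidin-1-yl)propyl or 4-(4-methylpiperazin-1-yl)butyl chain would separate them, while a morpholine or piperidine end remains untested among the compounds shown.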